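A halogen exchange on the phenyl ring of compound 1

The source may report more compounds than this note shows. Statements on the series, on what has been measured and on what is new or still open speak of the compounds shown alone.

Compound 1, `Cc1ccc(C2=NN(c3nc(-c4ccc(Br)cc4)cs3)C(c3ccc(F)cc3)C2)s1`, gives > 500 ug/mL in a functional assay on A549 cells (Homo sapiens) for antiproliferative activity, read by XTT assay, with a stated time of 24 h (a lower number here means a stronger inhibitor, a higher number a weaker inhibitor), a value that is a limit of the assay and not a number.
Compound 2, `Fc1ccc(C2CC(c3ccc(Cl)s3)=NN2c2nc(-c3ccc(Br)cc3)cs2)cc1`, gives 62.5 ug/mL in this assay.
Compound 3, `O=[N+]([O-])c1ccc(-c2csc(N3N=C(c4ccc(Cl)s4)CC3c3ccc(F)cc3)n2)cc1`, gives > 500 ug/mL in this assay, again a limit of the assay.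

Compound 1 thus stands at the limit of this assay, without a measured number of its own. Compound 4, `Cc1ccc(C2=NN(c3nc(-c4ccc(Cl)cc4)cs3)C(c3ccc(F)cc3)C2)s1`, differs from compound 1 by chloro in place of bromo on an aromatic carbon. Neither measured step is this exchange. an at least 8.0-fold lower number from compound 1 to compound 2 (0.90 log units; beyond the scatter) shows that a change on the thiophene ring can move the number, and an at least 8.0-fold higher number from compound 2 to compound 3 (0.90 log units; beyond the scatter) shows the same for the ring that carries the bromo group; both steps exchange groups far less alike than bromo and chloro. With compound 1 known only through (the limit of > 500 ug/mL in this assay, at which 2 of the 3 values shown sit), compound 4 is expected to remain near that limit, and a number no higher from compound 1 to compound 4 (the limit leaves the size open) is expected to be small. The estimate for compound 4 is 500 ug/mL, with a range from 125 ug/mL to 1000 ug/mL.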

Compound 4, half-maximal inhibitory concentration: > 500 ug/mL
Compound 4 gave a limit, no number (the forecaster's own chance of this, stated with the estimate: 70%); the middle value lies on the limit itself.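

Compound 1 and compound 4 both end at a limit of this assay, not at a number, so the step between them cannot be read: the limit of > 500 ug/mL in this assay, at which 3 of the 4 values shown sit.

The compounds shown leave open whether chloro in place of bromo on an aromatic carbon changes the number at all.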